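A few compounds are considered here, and "the series" means these few. Any claim that something is new, unique, unknown or untested is made for them only; others in the source may bear on it.

Among the compounds with values here, compound 2 `CC(C)c1noc(N2CCC(Oc3ncnc4c3CCN4c3ccc(S(C)(=O)=O)cc3F)CC2)n1` is one of two compounds measured in a functional assay on CHO-K1 cells for agonist activity at Glucose-dependent insulinotropic receptor (Homo sapiens), read by a luciferase reporter, with a stated time of 5 h; a lower number here means that less compound is needed, a higher number that more compound is needed for the effect; in this assay compound 2 gives 79.4 nM, the highest of the two numbers. The other measured compound, compound 1 `CC(C)SC(=O)N1CCC(Oc2ncnc3c2CCN3c2ccc(S(C)(=O)=O)cc2F)CC1`, gives 10 nM, and the step of a 7.9-fold higher number from compound 1 to compound 2 (0.90 log units; beyond the scatter) concerns the group on the amine nitrogen in a ring, a different part of the molecule from the one changed next. Compound 3 `Cc1nc(OC2CCN(c3nc(C(C)C)no3)CC2)c2c(n1)N(c1ccc(S(C)(=O)=O)cc1F)CC2` differs from compound 2 by methyl in place of hydrogen on an aromatic carbon. Within the data shown here, no measured step touches that aromatic carbon, so the two numbers in hand give no direct guide to the size or direction of this change. With nothing pointing either way, the expected step of a 1.1-fold lower number from compound 2 to compound 3 (0.05 log units; within the scatter) is small, inside the usual scatter. Compound 3 is therefore estimated at 70 nM, with a range from 25 nM to 250 nM.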

Compound 3, half-maximal effective concentration: 251 nM
For compound 3 the middle estimate is 3.6-fold (0.55 log units) below the measured one, and the stated range ends below it.
By their numbers in this assay, from the lowest: compound 1; then compound 2; then compound 3.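

Within the data shown here, the step of a 3.2-fold higher number from compound 2 to compound 3 (0.50 log units; beyond the scatter) is the first reading at this position: in this assay a single methyl on an aromatic carbon between two ring nitrogen atoms is enough to shift the number beyond the scatter, so more compound is needed for the effect. Changes at two separate places, this carbon and the amine nitrogen in a ring, have now each raised the number, and the position therefore cannot be treated as indifferent to substitution. No measurement at hand explains this rise. On these data alone, it remains open whether an ethyl group, a chlorine atom or an amine on the same carbon would raise the number as well. Also open, as far as these compounds go, is whether the methyl would have a similar effect alongside the (isopropylsulfanyl)carbonyl group of compound 1.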